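Shortening the amine substituent from cyclobutyl to methyl

The compounds below may be only part of what the source reports. "The series", "measured", "known", "first", "only" and "open" are said of these compounds alone.

Measured compounds:
compound 1 `CCCCNc1nc(-c2ccccc2)nc2c1nnn2Cc1ccccc1`, 11000000 nM
compound 2 `c1ccc(Cn2nnc3c(NC4CCC4)nc(-c4ccccc4)nc32)cc1`, 5000000 nM

Among the measured compounds shown here, in an assay on isolated protein for binding affinity to adenosine receptor A1 (Bos taurus) (on this read-out lower numbers stand for stronger inhibition and higher numbers for weaker inhibition), compound 1 gives 11000000 nM, while compound 2 gives 5000000 nM, so compound 2 stands at the lower of the two numbers, with compound 1 the only neighbour, the step being a 2.2-fold lower number from compound 1 to compound 2 (0.34 log units; beyond the scatter). Compound 3 `CNc1nc(-c2ccccc2)nc2c1nnn2Cc1ccccc1` has not yet been measured. The change from compound 2 to compound 3 is methyl in place of cyclobutyl on a nitrogen on an aromatic ring. For the measured compounds named here, no measured step shows this change; the one step known, a 2.2-fold lower number from compound 1 to compound 2 (0.34 log units; beyond the scatter), concerns a different pair of groups at the same nitrogen and was modest. With only that to go on, a modest step is expected, most likely toward a higher number. Compound 3 is therefore expected to give about 12000000 nM, in a range from 4000000 nM to 40000000 nM. The expected step is a 2.4-fold higher number from compound 2 to compound 3 (0.38 log units; beyond the scatter).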

Compound 3, inhibition constant: 353000000 nM
For compound 3 the middle estimate is 29-fold (1.47 log units) below the measured one; measured number above the stated range.
By their numbers in this assay, from the lowest: compound 2; then compound 1; then compound 3.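

In this assay, the group on this nitrogen turns out to matter far more than the earlier pair suggested: methyl in place of cyclobutyl brings a 71-fold higher number from compound 2 to compound 3 (1.85 log units; beyond the scatter), and methyl against butyl brings a 32-fold higher number from compound 1 to compound 3 (1.51 log units; beyond the scatter), both large. Among the compounds shown here, the only earlier step, a 2.2-fold lower number from compound 1 to compound 2 (0.34 log units; beyond the scatter), is modest by comparison and joins the two larger groups, so butyl and cyclobutyl lie fairly close together while methylamino stands well apart at the weak end of the three. No measured evidence accompanies these numbers to account for the gap.

The compounds shown leave open where ethyl, propyl or cyclopropyl on this nitrogen would fall relative to methyl and the larger groups. They also leave open whether a longer chain such as hexyl, or a larger ring such as cyclohexyl, would lower the number further.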